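Antiproliferative activity of a shared core with altered amide substituents

The source may hold more compounds than are shown below. What is called first, only, known or untested is meant among the compounds shown, and "the series" means these compounds.

Measured compounds:
- compound 1, `C=C(C)C(=O)Nc1cc2c(N3CCc4ccccc43)ncnc2cc1OC`: 11100 nM
- compound 2, `CC(C)/C=C/C(=O)Nc1cc2c(N3CCCc4ccccc43)ncnc2cc1O[C@@H]1CCOC1`: 4680 nM

Both compounds were tested in a functional assay on MCF7 cells (Homo sapiens) for antiproliferative activity, read by MTT assay, with a stated time of 72 h; a higher number here means a weaker inhibitor, a lower number a stronger inhibitor. Of the two numbers, compound 1 has the highest, and in this assay compound 1 gives 11100 nM, while compound 2 gives 4680 nM, a lower number that lies beyond the usual scatter. Compound 2 differs from compound 1 in more than one place, so no single structural change can be tied to that gap.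

The unmeasured compound 3, `COc1cc2ncnc(N3CCc4ccccc43)c2cc1NC(=O)/C=C/CN1CCN(C)CC1`, shares the core of compound 1 and changes only the group on the carbonyl carbon: 3-(4-methylpiperazin-1-yl)prop-1-en-1-yl in place of 1-methylethenyl on a carbonyl carbon. Among the measured compounds shown here, no step between two measured compounds changes this same position, so the size of the effect is uncertain. Given that the one other variation seen, from compound 1 to compound 2, led to a lower number, a moderate drop is expected here too, and compound 3 is estimated to give 5000 nM, with a likely range from 1500 nM to 15000 nM. The expected step from compound 1 to compound 3 is a 2.2-fold lower number from compound 1 to compound 3 (0.35 log units; beyond the scatter), beyond the scatter but not large.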

Compound 3, half-maximal inhibitory concentration: 6430 nM
Compound 3: middle estimate off by 1.3-fold (0.11 log units), on the low side; low and high end bracket the measured number.
By their numbers in this assay, from the lowest: compounds 2, 3 and 1 (each within the scatter of the next, the first and the last beyond it).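

In this assay the exchange of 1-methylethenyl for 3-(4-methylpiperazin-1-yl)prop-1-en-1-yl on a carbonyl carbon gives a 1.7-fold lower number from compound 1 to compound 3 (0.24 log units; within the scatter) and so stays within the usual scatter of repeated measurements. Among the compounds shown here, this is the first comparison in which only this position differs, and it shows that a group of 10 heavy atoms carrying a six-membered non-aromatic ring can replace one of 3 heavy atoms with no difference that can be told from that scatter. Nothing among the data shown offers an explanation for this outcome.

Going by these compounds, what a morpholine ring or a dimethylamino group would do on the same prop-1-en-1-yl chain stays open, so the contribution of the 4-methylpiperazin-1-yl ring cannot yet be separated from that of the chain carrying it. On these data alone, compound 2 cannot settle this question, since it differs from compound 1 in more than one place, and the separate effects of its changes remain unknown.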